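From 4-methylphenyl to phenyl: an estimate for compound 4

The source may report more compounds than this note shows. Statements on the series, on what has been measured and on what is new or still open speak of the compounds shown alone.

Compound 1 `COc1ccc(/C=C/c2cc(OC)cc(OC)c2/C=C/C(=O)c2ccc(C)cc2)cc1` gives the lowest of three numbers in a functional assay on A549 cells (Homo sapiens) for antiproliferative activity, read by MTT assay, with a stated time of 48 h (on this read-out higher numbers stand for weaker inhibition and lower numbers for stronger inhibition), at 3.6 ug/mL. Its bromo analogue, compound 2 `COc1ccc(/C=C/c2cc(OC)cc(OC)c2/C=C/C(=O)c2ccc(Br)cc2)cc1`, gives 8.3 ug/mL, and its fluoro analogue, compound 3 `COc1ccc(/C=C/c2cc(OC)cc(OC)c2/C=C/C(=O)c2ccc(F)cc2)cc1`, gives 6.6 ug/mL. The step of a 2.3-fold higher number from compound 1 to compound 2 (0.36 log units; beyond the scatter) lies beyond the scatter, whereas a 1.8-fold higher number from compound 1 to compound 3 (0.26 log units; within the scatter) and a 1.3-fold lower number from compound 2 to compound 3 (0.10 log units; within the scatter) do not. Compound 4 `COc1ccc(/C=C/c2cc(OC)cc(OC)c2/C=C/C(=O)c2ccccc2)cc1` has not been measured; it differs from compound 1 by hydrogen in place of methyl on an aromatic carbon. For the measured compounds named here, no measured step replaces that methyl with hydrogen, but both measured replacements of it moved the number upward, once modestly. For compound 4 a step no larger than those, in the same direction and likely within the scatter, is therefore expected: a 1.4-fold higher number from compound 1 to compound 4 (0.14 log units; within the scatter). Compound 4 is estimated at 5 ug/mL, with a range of 2.5 ug/mL to 10 ug/mL.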

Compound 4, half-maximal inhibitory concentration: 3.9 ug/mL
Estimate against measurement, compound 4: 1.3-fold (0.11 log units) above; the measured number falls inside the stated range.
By their numbers in this assay, from the lowest: compounds 1, 4, 3 and 2 (each within the scatter of the next, the first and the last beyond it).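

Losing the methyl altogether leaves the number within the scatter, a 1.1-fold higher number from compound 1 to compound 4 (0.03 log units; within the scatter), so at this position the methyl is not required for the activity seen with compound 1. Hydrogen in place of fluoro also stays within the scatter, a 1.7-fold lower number from compound 3 to compound 4 (0.23 log units; within the scatter), whereas hydrogen in place of bromo is the only new step beyond it, a 2.1-fold lower number from compound 2 to compound 4 (0.33 log units; beyond the scatter), and a modest one. Nothing available here explains these small differences.

The compounds shown leave open whether an amine or a carboxylic acid at this position would move the number in this assay further than these groups do.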